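The compounds below may be only part of what the source reports. "The series", "measured", "known", "first", "only" and "open" are said of these compounds alone.

Within the data shown here, compound 3 `CC(/N=C(\NC#N)Nc1ccncc1)C1CC1` stands second highest of the three numbers so far in a functional assay on the whole organism (blood, strain Wistar-Okamoto) with Rattus norvegicus as the target, with a stated time of 5 days; on this read-out higher numbers stand for an effect only at larger amounts of compound and lower numbers for an effect already at smaller amounts: compound 3 gives 3 mg/kg, nearest to compound 2 `CC(C)(C)C/N=C(\NC#N)Nc1ccncc1`, which gives 5 mg/kg, and furthest from compound 1 `CCC(C)(CC)/N=C(\NC#N)Nc1cccnc1`, which gives 0.5 mg/kg. Compound 4 `CCC(C)(CC)/N=C(\NC#N)Nc1ccncc1` differs from compound 3 by 1-ethyl-1-methylpropyl in place of 1-cyclopropylethyl on a double-bonded nitrogen. Among the measured compounds shown here, the one measured step at the same position, a 1.7-fold lower number from compound 2 to compound 3 (0.22 log units; within the scatter), lay within the scatter. Compound 1 carries the same 1-ethyl-1-methylpropyl group yet differs elsewhere, so its value alone does not fix the step. Compound 4 is therefore expected to give 2 mg/kg, with a range of 0.7 mg/kg to 6 mg/kg. The step of a 1.5-fold lower number from compound 3 to compound 4 (0.18 log units; within the scatter) is expected to remain within the scatter.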

Compound 4, minimum effective dose: 0.5 mg/kg
For compound 4 the middle estimate is 4.0-fold (0.60 log units) above the measured one, outside the stated range (below it).
By their numbers in this assay, from the lowest: compounds 1 and 4 (each within the scatter of the next); then compounds 3 and 2 (each within the scatter of the next).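

Among these compounds, on the double-bonded nitrogen, 1-ethyl-1-methylpropyl brings the first change at this position beyond the scatter in this assay (a 6.0-fold lower number from compound 3 to compound 4 (0.78 log units; beyond the scatter)) and (a 10-fold lower number from compound 2 to compound 4 (1.00 log units; beyond the scatter)). With this group in place, pyridin-4-yl in place of pyridin-3-yl on the amine nitrogen makes no difference (no change at the digits printed from compound 1 to compound 4 (within the scatter)). No evidence at hand bears on these steps. From the compounds shown here alone, it remains open whether a cyclohexyl group or a longer chain on the double-bonded nitrogen would give as low a number. Going by these compounds, it also remains open whether the two pyridinyl groups stay level with any other group there.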